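Swapping Bromo for Hydroxy on the Outer Amide Ring

A few compounds are considered here, and "the series" means these few. Any claim that something is new, unique, unknown or untested is made for them only; others in the source may bear on it.

Compound 3 `CN(C)C(=O)c1cc2cnc(Nc3ccc(NC(=O)C4(C(=O)Nc5ccc(Br)cc5)CC4)cc3)nc2n1C1CCCC1` gives 23.2% in a functional assay on SiHa cells (Homo sapiens) for inhibition, read by CCK-8 assay, with a stated time of 72 h, tested at 1 uM (on this read-out lower numbers stand for less inhibition of growth and higher numbers for more inhibition of growth at the one concentration tested), the highest of the three numbers measured. Compound 2 `CN(C)C(=O)c1cc2cnc(Nc3ccc(NC(=O)C4(C(=O)Nc5ccc(F)cc5)CC4)cc3F)nc2n1C1CCCC1` gives 6.6%, and compound 1 `CN(C)C(=O)c1cc2cnc(Nc3ccc(NC(=O)C4(C(=O)Nc5cccc(O)c5)CC4)cc3)nc2n1C1CCCC1` gives -19.8%. Compound 4 `CN(C)C(=O)c1cc2cnc(Nc3ccc(NC(=O)C4(C(=O)Nc5ccc(O)cc5)CC4)cc3)nc2n1C1CCCC1` is not yet measured; it differs from compound 3 in a single place: hydroxy in place of bromo on an aromatic carbon. For the measured compounds named here, one measured step bears on this change, though the hydroxy there sat as 3-hydroxyphenyl rather than 4-hydroxyphenyl: a number 43 percentage points higher from compound 1 to compound 3 (beyond the scatter). Because a number 43 percentage points higher from compound 1 to compound 3 (beyond the scatter) accompanied bromo entering in place of hydroxy, the reverse swap in compound 4 is expected to lower growth inhibition, a step of about a number 28.2 percentage points lower from compound 3 to compound 4 (beyond the scatter). Compound 4 is therefore estimated at -5%, with a range from -30% to 20%.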

Compound 4, percent growth inhibition at one concentration: 69.5%
Beside the measured number, compound 4's estimate is 74.5 percentage points below it; the whole stated range lies below it.
By their numbers in this assay, from the lowest: compound 1; then compound 2; then compound 3; then compound 4.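

With a number 46.3 percentage points higher from compound 3 to compound 4 (beyond the scatter) in this assay on swapping bromo for hydroxy, the earlier picture of hydroxy as the poorer group on this ring no longer holds. Where the hydroxy sits matters greatly: a number 89.3 percentage points higher from compound 1 to compound 4 (beyond the scatter) comes with moving from 3-hydroxyphenyl to 4-hydroxyphenyl. Nothing shown here explains either step.

Still open, on these data alone, is whether an amine or a carboxylic acid at this same place on the ring would match hydroxy. Also open, as far as these compounds go, is whether a methoxy group there would keep the gain.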